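Acyl group change on the shared core: compound 3

The source may report more compounds than this note shows. Statements on the series, on what has been measured and on what is new or still open speak of the compounds shown alone.

- compound 1 `CC1(C)c2[nH]nc(NC(=O)c3ccc(F)cc3)c2CN1C(=O)C1CCN(C2CC2)CC1` gives 380 nM in the series
- compound 2 `CC(C)(C)C(=O)N1Cc2c(NC(=O)c3ccc(F)cc3)n[nH]c2C1(C)C` gives 270 nM in the series

In a functional assay on A2780 cells (Homo sapiens) for antiproliferative activity, read by fluorescence, with a stated time of 72 h (on this read-out lower numbers stand for stronger inhibition and higher numbers for weaker inhibition), compound 2 gives 270 nM and stands level with compound 1 within the scatter. Compound 3 `CC(=O)N1CCC(C(=O)N2Cc3c(NC(=O)c4ccc(F)cc4)n[nH]c3C2(C)C)CC1` differs from compound 2 as follows: 1-acetylpiperidin-4-yl in place of tert-butyl on a carbonyl carbon. Among the compounds with values here, the one measured step at this carbonyl carbon, tert-butyl in place of 1-cyclopropylpiperidin-4-yl, is a 1.4-fold lower number from compound 1 to compound 2 (0.15 log units; within the scatter) and gives no change beyond the scatter. Within the data shown here, no measured compound carries the acetyl group, so that part remains untested. No step beyond the scatter is therefore expected in this assay in either direction. The estimated size is a 1.3-fold higher number from compound 2 to compound 3 (0.11 log units; within the scatter) at this stage. Compound 3 is estimated at 350 nM with an expected range of 150 nM to 800 nM in repeat measurements.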

Compound 3, half-maximal inhibitory concentration: > 10000 nM
Compound 3: a limit, no number (the forecaster's own chance of this, stated with the estimate: 2%); middle value at least 28-fold (1.45 log units) away from the limit.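

In this assay compound 3 reads as a limit and not as a number: the limit of > 10000 nM in this assay, at which 1 of the 3 values shown sits.

The earlier step at the carbonyl carbon lay within the scatter, but this position is not indifferent to its substituent: 1-acetylpiperidin-4-yl in place of tert-butyl gives an at least 37-fold higher number from compound 2 to compound 3 (1.56 log units; beyond the scatter). The ring itself does not account for the loss, as acetyl in place of cyclopropyl on the amine nitrogen in a ring gives an at least 26-fold higher number from compound 1 to compound 3 (1.42 log units; beyond the scatter), so among these compounds the large step follows the group on that nitrogen.

The compounds shown leave open whether a free secondary amine, a methyl group or a longer acyl chain on that nitrogen would side with compound 1 or with compound 3. They also cannot tell how far a carboxylic acid or an ether on the carbonyl carbon would be accepted.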